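The source may hold more compounds than are shown below. What is called first, only, known or untested is meant among the compounds shown, and "the series" means these compounds.

Of the compounds shown here, two have been measured in an assay on isolated protein for inhibition of matrix metalloproteinase-9 (Homo sapiens); a lower number here means a stronger inhibitor, a higher number a weaker inhibitor. Compound 1, with the structure `COc1ccc(-c2cnc(-c3ccc(S(=O)(=O)NC(CCC(=O)O)C(=O)O)cc3)s2)cc1`, gives 50 nM. Compound 2, with the structure `COc1ccc(-c2cnc(-c3ccc(S(=O)(=O)NC(C(=O)O)C(C)C)cc3)o2)cc1`, gives 1000 nM in this assay. Among the compounds with values here, of these two numbers the one for compound 2 is the higher, so compound 2 is the weaker inhibitor of the pair, and the gap between them lies beyond the usual scatter.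

Compound 3 is not yet measured; its structure is `COc1ccc(-c2cnc(-c3ccc(S(=O)(=O)NC(C(=O)NO)C(C)C)cc3)o2)cc1`. It differs from compound 2 in one place only: hydroxyamino in place of hydroxy on a carbonyl carbon. Within the data shown here, no measured pair shows this exact change here, so the size of the step is open. The expectation is nonetheless a clear move downward, well beyond the scatter, in this assay. For compound 3 the estimated value is 30 nM, with a range from 5 nM to 200 nM, which amounts to an expected step of a 33-fold lower number from compound 2 to compound 3 (1.52 log units; beyond the scatter).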

Compound 3, half-maximal inhibitory concentration: 1000 nM
Beside the measured number, compound 3's estimate is 33-fold (1.52 log units) below it; the whole stated range lies below it.
By their numbers in this assay, from the lowest: compound 1; then compounds 2 and 3 (each within the scatter of the next).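

In this assay, replacing hydroxy with hydroxyamino on this carbonyl carbon, which turns carboxy into hydroxycarbamoyl, gives no change at the digits printed from compound 2 to compound 3 (within the scatter). With the 2-methylpropyl part of the chain and the shared core held constant, this one swap therefore leaves the two numbers indistinguishable, so in this setting the added nitrogen and the extra hydrogen-bond donor of hydroxyamino show no measurable effect on the read-out. Nothing in the data explains this result. Compound 1 differs from compounds 2 and 3 in more than one place, so the compounds shown cannot say whether the same swap would behave differently in another setting, such as on the core and side chain of compound 1. Other groups on this carbonyl carbon, such as methylamino or methoxy, also remain open.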